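Bromo in place of hydrogen on compound 2

A few compounds are considered here, and "the series" means these few. Any claim that something is new, unique, unknown or untested is made for them only; others in the source may bear on it.

compound 1 `O=C1O/C(=C\Cn2cc(I)c(=O)[nH]c2=O)C(OCc2ccccc2)=C1OCc1ccccc1`: 80000 nM
compound 2 `O=C1O/C(=C\Cn2ccc(=O)[nH]c2=O)C(OCc2ccccc2)=C1OCc1ccccc1`: 30000 nM
compound 3 `O=C1O/C(=C\Cn2cnc3c(-n4cccc4)ncnc32)C(OCc2ccccc2)=C1OCc1ccccc1`: > 100000 nM

All values come from a functional assay on MIA PaCa-2 cells (Homo sapiens) for inhibition; on this read-out lower numbers stand for stronger inhibition and higher numbers for weaker inhibition. Compound 3 gives only a limit of the assay, > 100000 nM, and no number. Compound 2 has the lower of the two numbers, 30000 nM, and compound 1 is its nearest neighbour.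

Compound 4 `O=C1O/C(=C\Cn2cc(Br)c(=O)[nH]c2=O)C(OCc2ccccc2)=C1OCc1ccccc1` differs from compound 2 by bromo in place of hydrogen on an aromatic carbon, a bromo in place of hydrogen on an aromatic carbon. Among the measured compounds shown here, one measured step bears on this change: a 2.7-fold lower number from compound 1 to compound 2 (0.43 log units; beyond the scatter), where hydrogen replaces iodo. Reversed, that modest step suggests a halogen raises the number, though it is a single pair. For the measured compounds named here, a modest rise in this assay is therefore expected, no larger than that step, and the estimated step is a 1.8-fold higher number from compound 2 to compound 4 (0.26 log units; within the scatter). Compound 4 is estimated at 55000 nM, with an expected range of 25000 nM to 100000 nM.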

Compound 4, half-maximal inhibitory concentration: 80000 nM
Estimate against measurement, compound 4: 1.5-fold (0.16 log units) below, within the range that was stated.
By their numbers in this assay, from the lowest: compound 2; then compounds 1 and 4 (each within the scatter of the next). At a limit, above all of these: compound 3.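

In this assay, bromo on this aromatic carbon confirms with a second halogen what iodo suggested, a higher number than hydrogen gives: a 2.7-fold higher number from compound 2 to compound 4 (0.43 log units; beyond the scatter). Between the two halogens the series shows no separation: no change at the digits printed from compound 1 to compound 4 (within the scatter). Nothing shown accounts for this rise with either halogen.

Open, going by these compounds, is whether chloro or fluoro on this carbon would behave as bromo and iodo do. Also open, on these data alone, is whether a methyl, an amine or a carboxylic acid there would bring the number below that of compound 2.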